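A few compounds are considered here, and "the series" means these few. Any claim that something is new, unique, unknown or untested is made for them only; others in the source may bear on it.

Within the data shown here, in a functional assay on MDA-MB-231 cells (Homo sapiens) for antiproliferative activity, read by MTT assay, with a stated time of 72 h (a higher number here means a weaker inhibitor, a lower number a stronger inhibitor), compound 3 (`COc1cccc(-c2cccc(NC(=O)CCc3ccccc3)c2)c1`) gives 25000 nM as the lowest of the three numbers so far. Compound 4 (`COc1cc(OC)cc(-c2cccc(NC(=O)CCc3ccccc3)c2)c1`) differs from it by one change (methoxy in place of hydrogen on an aromatic carbon): methoxy in place of hydrogen on an aromatic carbon, meta to a methoxy group. Among the measured compounds shown here, no measured step isolates this change. The only one (a 1.2-fold higher number from compound 1 to compound 2 (0.08 log units; within the scatter)) lies within the scatter and concerns another part of the structure. Compound 1 (`COc1cc(OC)cc(-c2cccc(NC(=O)CCc3ccc4c(c3)COB4O)c2)c1`) at 77000 nM and compound 2 (`COc1cc(OC)cc(-c2cccc(NC(=O)CCc3cccc4c3COB4O)c2)c1`) at 93000 nM carry the methoxy groups of compound 4 and stand beyond the scatter from compound 3, but they also differ from it elsewhere, so they tilt the expectation only slightly upward. The step expected in this assay (a 1.2-fold higher number from compound 3 to compound 4 (0.08 log units; within the scatter)) stays within the scatter. For compound 4 the estimated value is 30000 nM (expected range 12000 nM to 70000 nM).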

Compound 4, half-maximal inhibitory concentration: 87000 nM
Compound 4: middle estimate off by 2.9-fold (0.46 log units), on the low side; the measured number lies above the stated range.
By their numbers in this assay, from the lowest: compound 3; then compounds 1, 4 and 2 (each within the scatter of the next).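

In this assay, among these compounds, methoxy in place of hydrogen on an aromatic carbon, meta to a methoxy group, gives the first isolated reading at this position: a 3.5-fold higher number from compound 3 to compound 4 (0.54 log units; beyond the scatter) and so a weaker compound. Among the compounds shown here, with both methoxy groups present, the six-carbon aromatic group in place of the group of 10 heavy atoms gives a 1.1-fold lower number from compound 2 to compound 4 (0.03 log units; within the scatter) and a 1.1-fold higher number from compound 1 to compound 4 (0.05 log units; within the scatter) and thus no separation between these compounds. No available data explain the methoxy step.
From the compounds shown here alone, whether the boron-containing groups would alter the single-methoxy compound 3 remains open. So does whether a hydroxyl or an amine at this position would track hydrogen or methoxy.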